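Moving a Methyl Group on an Aryl Urea

The compounds below may be only part of what the source reports. "The series", "measured", "known", "first", "only" and "open" are said of these compounds alone.

Of the compounds shown here, three from this series have been tested in a functional assay on HepG2 cells (Homo sapiens) for antiproliferative activity, read by MTT assay; a lower number here means a stronger inhibitor, a higher number a weaker inhibitor. Compound 1 `Cc1ccccc1NC(=O)Nc1cccc(CNc2ncnc3ccccc23)c1` carries a 2-methylphenyl group on an amide-type nitrogen whose other neighbour is a carbonyl carbon. In this assay compound 1 gives > 50000 nM, which is a limit of the assay and not a number. Compound 2 `Cc1cccc(NC(=O)Nc2cccc(CNc3ncnc4ccccc34)c2)c1` differs from it by 3-methylphenyl in place of 2-methylphenyl on an amide-type nitrogen. In this assay compound 2 gives > 50000 nM, again a limit. The step that the two limits leave unreadable from compound 1 to compound 2 therefore cannot be read, since both ends sit at the limit of > 50000 nM in this assay, at which 3 of the 3 values shown sit.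

Compound 3 `COc1cc2ncnc(NCc3cccc(NC(=O)Nc4ccccc4C)c3)c2cc1OC` returns to the 2-methylphenyl group but on a different core; the difference between the two cores is not broken down here. In this assay compound 3 gives > 50000 nM, which is once more a limit.

Compound 4 `COc1cc2ncnc(NCc3cccc(NC(=O)Nc4cccc(C)c4)c3)c2cc1OC` has not yet been measured. It stands to compound 3 as compound 2 stands to compound 1, with 3-methylphenyl in place of 2-methylphenyl on an amide-type nitrogen, and the place of the change is the same in both pairs, so this is the same change.

For compound 4 the step that the limit leaves unreadable from compound 3 to compound 4 is expected to be small, because compound 1, compound 2 and compound 3 all sit at the limit of > 50000 nM in this assay, at which 3 of the 3 values shown sit. Compound 4 is estimated to give 60000 nM. Compound 4 is expected to fall between 25000 nM and 200000 nM, most likely again as a limit.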

Compound 4, half-maximal inhibitory concentration: 21500 nM
Estimate against measurement, compound 4: 2.8-fold (0.45 log units) above; the whole stated range lies above it.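

In this assay, putting 3-methylphenyl in place of 2-methylphenyl on an amide-type nitrogen gives an at least 2.3-fold lower number from compound 3 to compound 4 (0.36 log units; beyond the scatter), so on the core of compound 3 the change lowers the number by more than the usual scatter, and only a minimum for the size of the step is known. The same change on the core of compound 1 cannot be read, since both compound 1 and compound 2 sit at a limit, so that pair neither supports nor contradicts the result, and the change is shown to lower the number on one core only. Only one pair can speak to carrying the change from core to core, because nearly all the values lie at a single limit: the limit of > 50000 nM in this assay, at which 3 of the 4 values shown sit.

The compounds shown leave open whether the core of compound 1 would respond to this change as the core of compound 3 does, and whether the lower number of compound 4 belongs to the methyl group's new place or to that place on this core alone. They also leave open what an amine or a carboxylic acid in place of the methyl group would do on either core.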